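A Larger Ether Group on Compound 3

The source may hold more compounds than are shown below. What is called first, only, known or untested is meant among the compounds shown, and "the series" means these compounds.

Of the compounds shown here, three sharing one core have been measured in an ADME assay on KB cells (Homo sapiens) for cytotoxicity; a higher number here means that more compound is needed for the effect, a lower number that less compound is needed. Compound 1 `COc1cc2c(c(OC)c1OC)C(=O)[C@]1(OC)C=C[C@H]2N(C(=O)OCC(C)C)N1C(=O)OCC(C)C` gives only a limit of the assay, > 300 ug/mL. Compound 2 `CCCCOc1c(OC)c(OC)cc2c1C(=O)[C@]1(OC)C=C[C@H]2N(C(=O)OCC(C)C)N1C(=O)OCC(C)C` gives 22.1 ug/mL. Compound 3 `CCCOc1c(OC)c(OC)cc2c1C(=O)[C@]1(OC)C=C[C@H]2N(C(=O)OCC(C)C)N1C(=O)OCC(C)C` gives 299 ug/mL, the higher of the two actual numbers, and its nearest neighbour is compound 2.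

Compound 4 `COc1cc2c(c(OCc3ccc(Cl)cc3)c1OC)C(=O)[C@]1(OC)C=C[C@H]2N(C(=O)OCC(C)C)N1C(=O)OCC(C)C` differs from compound 3 by 4-chlorophenyl in place of ethyl on a saturated chain carbon bound to an oxygen on an aromatic ring. Cut one bond further out, this reads propoxy to (4-chlorobenzyl)oxy.

Three measured steps change this same group. The data show an at least 13-fold lower number from compound 1 to compound 2 (1.13 log units; beyond the scatter), and also a 14-fold higher number from compound 2 to compound 3 (1.13 log units; beyond the scatter). The third, a number no higher from compound 1 to compound 3 (the limit leaves the size open), has no readable size because of the limit of > 300 ug/mL in this assay, at which 1 of the 3 values shown sits. Only compound 2 therefore shows a clear fall in the number, while compound 3 goes against any simple trend with group size. Going by the values given here, no measured compound carries an aromatic ring in this group, so the comparison is loose.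

A lower number is still expected, and the estimated step is a 7.5-fold lower number from compound 3 to compound 4 (0.87 log units; beyond the scatter). The estimate for compound 4 is 40 ug/mL, with an expected range from 8 ug/mL to 200 ug/mL.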

Compound 4, concentration for half-maximal effect: 42 ug/mL
The estimate for compound 4 lay 1.1-fold (0.02 log units) below the measured number; measured number inside the range.
By their numbers in this assay, from the lowest: compounds 2 and 4 (each within the scatter of the next); then compound 3. At a limit, above all of these: compound 1.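

In this assay, compound 4 is the first compound shown with an aromatic ring in this group, and 4-chlorophenyl brings a 7.1-fold lower number from compound 3 to compound 4 (0.85 log units; beyond the scatter), as well as an at least 7.1-fold lower number from compound 1 to compound 4 (0.85 log units; beyond the scatter). The change also gives a 1.9-fold higher number from compound 2 to compound 4 (0.28 log units; within the scatter), so a ring-bearing group and a plain propyl chain at this place, on a saturated chain carbon bound to an oxygen on an aromatic ring, give numbers that this assay cannot separate, and a low number here does not depend on the group being an unbranched chain. Compound 1 stands at a limit and not at a number, so the step from it has only a lower bound: the limit of > 300 ug/mL in this assay, at which 1 of the 4 values shown sits.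

The compounds shown leave open whether the chlorine matters at all, since a plain phenyl without it, or a methoxy or an amine in its place on the ring, would separate the effect of the ring from that of its substituent. They also leave open whether a longer chain than propyl would bring the number down further, or whether the sharp difference between ethyl and propyl is specific to those two chains.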